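A propyl to ethynyl swap at the assay limit

The source may hold more compounds than are shown below. What is called first, only, known or untested is meant among the compounds shown, and "the series" means these compounds.

Measured in an ADME assay on CEMx174 cells (Homo sapiens) for cytotoxicity; a lower number here means that less compound is tolerated, a higher number that more compound is tolerated:
Compound 1 `CC1=C(C(=O)O)C(c2cccc(O)c2)NC(=O)N1` gives > 10000 nM as a limit
Compound 2 `CC1=C(C(=O)OCc2ccccc2)C(c2cccc(O)c2)NC(=O)N1` gives > 10000 nM as a limit
Compound 3 `CCCC1=C(C(=O)OCC2CCCCC2)C(c2cccc(O)c2)NC(=O)N1` gives > 10000 nM as a limit

Compound 3 has no number of its own and stands with the other two compounds at the limit of > 10000 nM in this assay, at which 3 of the 3 values shown sit, in the record. Compound 4 `C#CC1=C(C(=O)OCC2CCCCC2)C(c2cccc(O)c2)NC(=O)N1` carries ethynyl in place of propyl on a double-bonded ring carbon and is otherwise the same as compound 3. Among the measured compounds shown here, the one measured step (a step that the two limits leave unreadable from compound 1 to compound 2) lies elsewhere in the structure and gives no size to carry over. No step beyond the scatter is therefore expected in this assay and no direction can be given. The expected step is a step that the limit leaves unreadable from compound 3 to compound 4 and another limit is the likeliest report. The estimate for compound 4 is 20000 nM with 8000 nM to 60000 nM as its expected range.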

Compound 4, half-maximal cytotoxic concentration: > 1000 nM
Compound 4 was reported as a limit; the forecaster's own chance of this, stated with the estimate: 85%; the middle value does not contradict the limit.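

Compound 3 and compound 4 are both reported only as limits in this assay, and the step between them cannot be read. The compounds shown leave open whether ethynyl in place of propyl alters the half-maximal cytotoxic concentration at all.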